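Lengthening the sulfur chain on a bicyclic acid

The source may hold more compounds than are shown below. What is called first, only, known or untested is meant among the compounds shown, and "the series" means these compounds.

Among the compounds with values here, compound 2 `CCCCSCC1C2CCC(O2)C1C/C=C\CCCC(=O)O`, measured in a functional assay on a cell-free system (plasma) for inhibition of thromboxane A2 receptor (Homo sapiens) (a lower number here means a stronger inhibitor, a higher number a weaker inhibitor), gives 1000 nM, the lowest of the two numbers known so far. Its closest relative, compound 1 `O=C(O)CCC/C=C\CC1C2CCC(O2)C1CSCCCc1ccccc1`, gives 5000 nM in this assay, and a 5.0-fold lower number from compound 1 to compound 2 (0.70 log units; beyond the scatter). Compound 3 `CCCCCCCSCC1C2CCC(O2)C1C/C=C\CCCC(=O)O` differs from compound 2 by propyl in place of hydrogen on a saturated chain carbon, four bonds along the chain from a sulfur. Within the data shown here, the one measured step swapped a phenyl for a methyl, so it bears only loosely on a plain chain extension. A small change, within or near the scatter, is therefore expected: a 1.4-fold lower number from compound 2 to compound 3 (0.15 log units; within the scatter). Compound 3 is estimated at 700 nM, in a range from 200 nM to 2500 nM.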

Compound 3, half-maximal inhibitory concentration: 42000 nM
The estimate for compound 3 lay 60-fold (1.78 log units) below the measured number, outside the stated range (above it).
By their numbers in this assay, from the lowest: compound 2; then compound 1; then compound 3.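

Adding propyl gives a 42-fold higher number from compound 2 to compound 3 (1.62 log units; beyond the scatter) in this assay, so at this position a plain chain extension can cost far more than a swap at the chain end might suggest. Butyl in place of phenyl gives an 8.4-fold higher number from compound 1 to compound 3 (0.92 log units; beyond the scatter) as well, which puts the longest plain chain behind the phenyl-ended chain here. No measurement at hand explains this loss.

Where between butyl and the chain of compound 3 the rise begins remains open, so a pentyl or hexyl on the sulfur would help locate it. On these data alone, how a chain ending in an amine would behave also remains unknown.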